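The source may hold more compounds than are shown below. What is called first, only, known or untested is meant among the compounds shown, and "the series" means these compounds.

Measured so far, all in a functional assay on MCF7 cells (Homo sapiens) for antiproliferative activity, read by MTT assay, with a stated time of 48 h (a lower number here means a stronger inhibitor, a higher number a weaker inhibitor), as the only read-out:
compound 1 `CN(C)CCNc1cc2c(cn1)cc(NC(=O)/C=C/c1ccccc1)c(=O)n2C` gives 27400 nM
compound 2 `COc1ccc(C(=O)Nc2cc3cnc(N4CCN(C)CC4)cc3n(C)c2=O)cc1` gives 35400 nM

Compound 1 stands level with compound 2: the two values lie within the scatter of each other, so the pair gives no ranking.

Compound 3 `CN(C)CCNc1cc2c(cn1)cc(NC(=O)c1ccncc1)c(=O)n2C` is compound 1 with one change, pyridin-4-yl in place of 2-phenylethenyl on a carbonyl carbon, counted as pyridin-4-yl in place of 2-phenylethenyl on a carbonyl carbon and with nothing else altered. For the measured compounds named here, no measured pair differs in one place only, so the data give no size for such a step. In this assay a small step towards weaker inhibition is expected, little beyond the scatter, though two values are thin support. The estimated change is a 1.5-fold higher number from compound 1 to compound 3 (0.16 log units; within the scatter) and remains modest. Compound 3 is expected at 40000 nM with an estimated range from 15000 nM to 100000 nM in this test.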

Compound 3, half-maximal inhibitory concentration: 36600 nM
Compound 3: middle estimate off by 1.1-fold (0.04 log units), on the high side; the range from low to high includes it.
By their numbers in this assay, from the lowest: compounds 1, 2 and 3 (each within the scatter of the next).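

Replacing 2-phenylethenyl with pyridin-4-yl on a carbonyl carbon gives a 1.3-fold higher number from compound 1 to compound 3 (0.13 log units; within the scatter) in this assay, so compound 1 and compound 3 stand level. At this carbonyl carbon, then, the double bond outside aromatic rings can go and a ring nitrogen can enter, with two fewer heavy atoms in all, without a difference that can be told from the scatter. No measurement on hand bears on why the two groups read alike.

Steps to compound 2 cannot be read, as it differs from compound 1 and compound 3 in more than one place. Still open, from the compounds shown here alone, is whether a group of another kind on this carbonyl carbon, such as a saturated amine like piperidin-4-yl, a carboxylic acid on the ring or a longer alkyl chain, would give a step beyond the scatter.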